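Demethylation of the aryl methoxy in a cytotoxicity series

The source may hold more compounds than are shown below. What is called first, only, known or untested is meant among the compounds shown, and "the series" means these compounds.

The series shares one core carrying a 4-methoxyphenyl group, and varies the substituent on the aromatic nitrogen. Compound 1 `COc1ccc(-c2cc3c(OC)cc(OC)cc3n(C)c2=O)cc1` gives 10000 nM in a functional assay on A-427 cells (Homo sapiens) for cytotoxicity, read by colorimetric assay and MTT assay; a higher number here means a weaker inhibitor, a lower number a stronger inhibitor. Compound 2 `CCN(CC)C(=O)Cn1c(=O)c(-c2ccc(OC)cc2)cc2c(OC)cc(OC)cc21` gives 10000 nM and compound 3 `COc1ccc(-c2cc3c(OC)cc(OC)cc3n(CCC(=O)OCc3ccccc3)c2=O)cc1` gives 10000 nM. Compound 1 stands level with both, as the steps of no change at the digits printed from compound 1 to compound 2 (within the scatter) and no change at the digits printed from compound 1 to compound 3 (within the scatter) show, and the step of no change at the digits printed from compound 2 to compound 3 (within the scatter) between the other two is likewise flat. None of the three changes at the nitrogen moved the read-out.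

Compound 4 `COc1cc(OC)c2cc(-c3ccc(O)cc3)c(=O)n(C)c2c1` differs from compound 1 at a different place: hydrogen in place of methyl on an oxygen on an aromatic ring. Among the measured compounds shown here, no measured step touches this position, so the three flat steps bear on it only indirectly, as a sign that the read-out has been insensitive to change so far. No step beyond the scatter is therefore expected, and the step of no change at the digits printed from compound 1 to compound 4 (within the scatter) is estimated as flat. Compound 4 is expected to give about 10000 nM, with a range of 4000 nM to 25000 nM.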

Compound 4, half-maximal inhibitory concentration: 10000 nM
Compound 4: middle estimate and measured number agree at the digits printed; low and high end bracket the measured number.
By their numbers in this assay, from the lowest: compounds 1, 2, 3 and 4 (each within the scatter of the next).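

Methoxy to hydroxy on the 4-methoxyphenyl group is the only change shown away from the substituent on the aromatic nitrogen, and in this assay it gives no change at the digits printed from compound 1 to compound 4 (within the scatter). The flat read-out therefore extends to a second place on the molecule: with hydrogen in place of methyl on this oxygen on an aromatic ring, compound 4 gives 10000 nM. No measurement available here offers an explanation for this flat step.

Still open, going by these compounds, is whether an amine or a carboxylic acid in place of the hydroxy of compound 4, or a longer chain on that oxygen, would move the read-out. Also open, on these data alone, is whether the same methoxy to hydroxy change on the other methoxy groups of the shared core, or its pairing with the diethylcarbamoyl side chain of compound 2, would stay equally flat.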